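The compounds below may be only part of what the source reports. "The series", "measured", "known", "first", "only" and "open" are said of these compounds alone.

Series notes. Compound 1 `CCC(=O)Nc1ccc(S(=O)(=O)Oc2ccccc2C(C)C)cc1` gives 11000 nM in a functional assay on M21 cells (Homo sapiens) for antiproliferative activity, read by sulforhodamine B assay, with a stated time of 48 h; on this read-out lower numbers stand for stronger inhibition and higher numbers for weaker inhibition. Compound 2 `CC(C)c1ccccc1OS(=O)(=O)c1ccc(NC(=O)C(C)(C)C)cc1` gives 6200 nM and compound 3 `CC(C)(C)C(=O)Nc1ccc(S(=O)(=O)Oc2ccccc2I)cc1` gives 8300 nM in this assay. Compound 2 holds the lowest of the three numbers, yet both other compounds lie within the scatter of it, so no order among the three can be read. Compound 4 `CC(C)c1ccccc1OS(=O)(=O)c1ccc(NC(=O)NCC2CCCC2)cc1` is not yet measured; it differs from compound 2 by (cyclopentylmethyl)amino in place of tert-butyl on a carbonyl carbon. Going by the values given here, the one measured step at the same carbonyl carbon, a 1.8-fold lower number from compound 1 to compound 2 (0.25 log units; within the scatter), stayed within the scatter; the step of a 1.3-fold higher number from compound 2 to compound 3 (0.13 log units; within the scatter) concerns another place and also stayed within it. Among the compounds with values here, no measured step brings a (cyclopentylmethyl)amino group in, so only a small step, a 1.1-fold higher number from compound 2 to compound 4 (0.05 log units; within the scatter), of uncertain direction is expected in this assay. Compound 4 is therefore estimated at 7000 nM, within a range from 2500 nM to 20000 nM.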

Compound 4, half-maximal inhibitory concentration: 6600 nM
Compound 4: middle estimate off by 1.1-fold (0.03 log units), on the high side; low and high end bracket the measured number.
By their numbers in this assay, from the lowest: compounds 2, 4, 3 and 1 (each within the scatter of the next).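

In this assay the carbonyl carbon now carries (cyclopentylmethyl)amino, which brings in a five-membered non-aromatic ring and a hydrogen-bond donor, a far larger change than the earlier swap of ethyl for tert-butyl. Even so, the new group leaves the number with a 1.1-fold higher number from compound 2 to compound 4 (0.03 log units; within the scatter) and with a 1.7-fold lower number from compound 1 to compound 4 (0.22 log units; within the scatter) so this change at this position shows no effect that can be read. Nothing measured bears on why.

As far as these compounds go, whether a carboxylic acid, a primary amine or a longer chain on this carbonyl carbon would give a step beyond the scatter stays open. Also open, from the compounds shown here alone, is how (cyclopentylmethyl)amino reads with iodo in place of isopropyl on the aromatic carbon.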